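The source may hold more compounds than are shown below. What is called first, only, known or untested is meant among the compounds shown, and "the series" means these compounds.

Measured in a functional assay; on this read-out lower numbers stand for stronger inhibition and higher numbers for weaker inhibition:
Compound 1 `CC(C)=CCOc1cc(O)c2c(c1)OC(c1ccc(Cl)cc1Cl)CC2=O`: 3340 nM
Compound 2 `CC(C)=CCOc1cc(O)c2c(c1)OC(c1ccc(C)cc1)CC2=O`: 4360 nM

In this assay, compound 2 gives 4360 nM, within the scatter of compound 1. Compound 3 `CC(C)=CCOc1cc(O)c2c(c1)OC(c1ccc(O)cc1)CC2=O` has hydroxy in place of methyl on an aromatic carbon, para to a large group: hydroxy in place of methyl on an aromatic carbon. Within the data shown here, only one measured step touches this group, a 1.3-fold higher number from compound 1 to compound 2 (0.12 log units; within the scatter), and it stays within the scatter. Among the measured compounds shown here, no measured step introduces a hydroxy, so the evidence is thin, and no step beyond the scatter is expected. The expected step is a 1.2-fold lower number from compound 2 to compound 3 (0.10 log units; within the scatter). For compound 3 the estimated value is 3500 nM, with an expected range from 1300 nM to 10000 nM.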

Compound 3, half-maximal inhibitory concentration: 5340 nM
Compound 3: the middle estimate sits 1.5-fold (0.18 log units) below what was measured; measured number inside the range.
By their numbers in this assay, from the lowest: compounds 1, 2 and 3 (each within the scatter of the next).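

In this assay, hydroxy in place of methyl on the aromatic carbon gives a 1.2-fold higher number from compound 2 to compound 3 (0.09 log units; within the scatter), so a group that adds a hydrogen-bond donor at this place still leaves the read-out within the scatter. The wider comparison reads the same way: 4-hydroxyphenyl in place of 2,4-dichlorophenyl gives a 1.6-fold higher number from compound 1 to compound 3 (0.20 log units; within the scatter). No measurement at hand explains this result.

All three compounds lie within the scatter of one another, so no group shown here separates from the rest. As far as these compounds go, whether an amine or a carboxylic acid at this place would do so remains open.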